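Methoxy in Place of Fluoro: an Expected Partial Recovery

This account rests on a few compounds, and the source may have more. Where it says the series, first, only, none or still open, it means among the compounds named here.

Within the data shown here, compound 2 `CC(C)Cc1ccc(C(C)C(=O)N2CCN(c3ccc(F)cc3)CC2)cc1` holds the highest of the two numbers measured so far: in an assay on brain for inhibition of Fatty-acid amide hydrolase 1 (Rattus norvegicus), read by scintillation counting, with a stated time of 10 min (on this read-out lower numbers stand for stronger inhibition and higher numbers for weaker inhibition), compound 2 gives 17000 nM, whereas compound 1 `CC(C)Cc1ccc(C(C)C(=O)N2CCN(c3ccc(Cl)cc3)CC2)cc1` gives 1700 nM. Among the measured compounds shown here, the single measured step, a 10-fold higher number from compound 1 to compound 2 (1.00 log units; beyond the scatter), is the only guide available. Compound 3 `COc1ccc(N2CCN(C(=O)C(C)c3ccc(CC(C)C)cc3)CC2)cc1` differs from compound 2 by methoxy in place of fluoro on an aromatic carbon. For the measured compounds named here, no measured step covers methoxy itself, so the direction rests on compound 1 sitting at 1700 nM with chloro in place of fluoro. Compound 3 is therefore expected to move back, with a 3.4-fold lower number from compound 2 to compound 3 (0.53 log units; beyond the scatter). Compound 3 is estimated at 5000 nM, within a range of 1500 nM to 17000 nM.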

Compound 3, half-maximal inhibitory concentration: 4500 nM
Beside the measured number, compound 3's estimate is 1.1-fold (0.05 log units) above it, within the range that was stated.
By their numbers in this assay, from the lowest: compound 1; then compound 3; then compound 2.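

In this assay the position proves sensitive beyond the two halogens: the methoxy change gives a 3.8-fold lower number from compound 2 to compound 3 (0.58 log units; beyond the scatter) and, measured against chloro, a 2.6-fold higher number from compound 1 to compound 3 (0.42 log units; beyond the scatter) in the same series. The order of the para groups is thus chloro, then methoxy, then fluoro, with all three separated beyond the scatter, so compound 1 remains the strongest of the three. No measurement here accounts for that order.

From the compounds shown here alone, whether bromo, an amine or a longer chain on the oxygen would reach below compound 1 stays open. So does whether the same order would hold with the group elsewhere on the ring.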